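Changing the sulfonyl group of compound 2

This account rests on a few compounds, and the source may have more. Where it says the series, first, only, none or still open, it means among the compounds named here.

In an ADME assay on microsomes from liver (Homo sapiens) for metabolic stability, read by LC-MS, with a stated time of 30 min, tested at 1 uM (a lower number here means that less of the compound is left, a higher number that more of the compound is left), compound 1 (`Cc1ccccc1S(=O)(=O)c1ccc(CNC(=O)c2cc3cnccc3[nH]2)cc1`) gives 48% and compound 2 (`O=C(NCc1ccc(S(=O)(=O)c2ccccc2C(F)(F)F)cc1)c1cc2cnccc2[nH]1`) gives 52%. Going by the values given here, these two numbers lie within the scatter of each other, so compound 2 stands level with the only other compound measured so far.

Compound 3 (`O=C(NCc1ccc(S(=O)(=O)c2cc(F)cc(F)c2)cc1)c1cc2cnccc2[nH]1`) differs from compound 2 in one place: 3,5-difluorophenyl in place of 2-(trifluoromethyl)phenyl on a sulfonyl sulfur. Put simply, 3,5-difluorophenyl stands in place of 2-(trifluoromethyl)phenyl on a sulfonyl sulfur.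

Among the compounds with values here, one measured step bears on this change: a number 4 percentage points higher from compound 1 to compound 2 (within the scatter), with trifluoromethyl in place of methyl on an aromatic carbon. That step altered the group that now leaves, and it stayed small. Within the data shown here, it offers only a weak guide, however, since no measured compound carries the 3,5-difluorophenyl group, and the data therefore point in neither direction.

The expected result is no step beyond the scatter, and the estimate is a number 2 percentage points lower from compound 2 to compound 3 (within the scatter). With so little to go on, the range is kept wide. For compound 3 the estimated value is 50%, with an expected range from 30% to 70%.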

Compound 3, percent of the compound remaining: 82%
Compound 3: middle estimate off by 32 percentage points, on the low side; measured number above the stated range.
By their numbers in this assay, from the lowest: compounds 1 and 2 (each within the scatter of the next); then compound 3.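

In this assay the group on the sulfonyl sulfur turns out to matter: 3,5-difluorophenyl in place of 2-(trifluoromethyl)phenyl gives a number 30 percentage points higher from compound 2 to compound 3 (beyond the scatter) and the same group in place of 2-methylphenyl gives a number 34 percentage points higher from compound 1 to compound 3 (beyond the scatter). The earlier pair showed only that trifluoromethyl in place of methyl on this ring leaves the number within the scatter, while these two steps show that a different pattern of groups on the ring can move it well beyond the scatter, and in the same direction from both starting compounds. No measurement at hand accounts for the rise.

The 3,5-difluorophenyl group differs from the two groups it replaces in more than one feature, so the compounds shown do not tell whether the two fluorines themselves go with the higher number or whether simply losing the methyl or trifluoromethyl group would be enough. On these data alone, a plain phenyl group, a ring with a single fluorine, and rings carrying a methoxy group or a nitrile remain open, as does whether the same step would hold on a changed core.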